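Swapping the amide-bound aryl group: compound 1 to compound 4

This account rests on a few compounds, and the source may have more. Where it says the series, first, only, none or still open, it means among the compounds named here.

Measured compounds:
- compound 1 `COc1ccc2c(=O)c(/C=C/C(=O)Nc3cccc(Cl)c3)coc2c1`: 1100000 nM
- compound 2 `COc1ccc2c(=O)c(/C=C/C(=O)NCc3ccc(F)cc3)coc2c1`: 133000 nM
- compound 3 `COc1ccc2c(=O)c(/C=C/C(=O)Nc3ccc(F)cc3)coc2c1`: 743000 nM

Of the compounds shown here, three sharing one core have been tested in an ADME assay on HepG2 2.2.15 cells (Homo sapiens) for cytotoxicity, read by MTT assay, with stated times of 48 h and 9 days; a lower number here means that less compound is tolerated, a higher number that more compound is tolerated. Compound 1 gives the highest number of the three; compound 3 sits nearest, and the step of a 1.5-fold lower number from compound 1 to compound 3 (0.17 log units; within the scatter) lies within the scatter, so the two cannot be told apart. Compound 2 sits furthest away, with the step of an 8.3-fold lower number from compound 1 to compound 2 (0.92 log units; beyond the scatter) beyond the scatter.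

The unmeasured compound 4 `COc1ccc2c(=O)c(/C=C/C(=O)Nc3ccc(C)cc3)coc2c1` differs from compound 1 in one place: 4-methylphenyl in place of 3-chlorophenyl on an amide-type nitrogen

For the measured compounds named here, only one measured step bears on this: the step from compound 1 to compound 3, which also exchanges the aryl group on the amide-type nitrogen for another aryl group and stays within the scatter. The step to compound 2 replaces the aryl group with a benzyl group, a different kind of change, and is set aside. For compound 4 in this assay, no step beyond the scatter is therefore expected, a 1.2-fold lower number from compound 1 to compound 4 (0.09 log units; within the scatter), and the estimated value is 900000 nM, with a range from 400000 nM to 2000000 nM.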

Compound 4, half-maximal cytotoxic concentration: 979000 nM
The estimate for compound 4 lay 1.1-fold (0.04 log units) below the measured number; measured number inside the range.
By their numbers in this assay, from the lowest: compound 2; then compounds 3, 4 and 1 (each within the scatter of the next).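

In this assay, the change to compound 4 gives a 1.1-fold lower number from compound 1 to compound 4 (0.05 log units; within the scatter), and the swap of methyl for fluoro on an aromatic carbon gives a 1.3-fold higher number from compound 3 to compound 4 (0.12 log units; within the scatter), so a carbon-only methyl group on the phenyl ring cannot be told apart from the chloro or fluoro groups tested there. Compound 2 stays apart from this new member as well, with a 7.4-fold higher number from compound 2 to compound 4 (0.87 log units; beyond the scatter), which means that compounds 1, 3 and 4 form a close set and the 4-fluorobenzyl group alone goes against it. Nothing measured here offers a reason for either observation.

Going by these compounds, whether the number would hold with an amine or a carboxylic acid on the phenyl ring remains open. So does the effect of a chain longer than the benzyl group on the amide-type nitrogen.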